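Anilino for dipropylamino on a rearranged quinone core

This account rests on a few compounds, and the source may have more. Where it says the series, first, only, none or still open, it means among the compounds named here.

Measured so far:
compound 1 `CCCN(CCC)C1=CC(=O)c2nc3n(c2C1=O)[C@H]1OC[C@@H](O)[C@H]1OC3` gives > 16000 nM, a limit of the assay.
compound 2 `O=C1C=C(Nc2cccc(Cl)c2)C(=O)c2c1nc1n2[C@H]2OC[C@@H](O)[C@H]2OC1` gives 4720 nM.
compound 3 `CCCN(CCC)C1=CC(=O)c2c(nc3n2[C@H]2OC[C@@H](O)[C@H]2OC3)C1=O` gives > 16000 nM, a limit of the assay.

All values come from a functional assay on MCF7 cells (Homo sapiens) for inhibition, read by sulforhodamine B assay; on this read-out lower numbers stand for stronger inhibition and higher numbers for weaker inhibition. Within the core of compound 1, the change (3-chlorophenyl)amino in place of dipropylamino on a double-bonded ring carbon made a step of an at least 3.3-fold lower number from compound 1 to compound 2 (0.53 log units; beyond the scatter). Compound 3 has the same atoms as compound 1, joined differently; the difference between the two cores is not broken down here. Compound 3 sits at the limit, and the limit of > 16000 nM in this assay, at which 2 of the 3 values shown sit, holds for the series as it stands.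

Compound 4 `O=C1C(Nc2cccc(Cl)c2)=CC(=O)c2c1nc1n2[C@H]2OC[C@@H](O)[C@H]2OC1` is not yet measured. It differs from compound 3 by (3-chlorophenyl)amino in place of dipropylamino on a double-bonded ring carbon, the same change as that from compound 1 to compound 2, at a place described in the same words. A step of about an at least 2.9-fold lower number from compound 3 to compound 4 (0.46 log units; beyond the scatter) is expected, set beside the earlier one of an at least 3.3-fold lower number from compound 1 to compound 2 (0.53 log units; beyond the scatter), because the value of compound 3 is only a limit, > 16000 nM, so the size of the expected step rests on the measured pair alone. For compound 4 a value near 5500 nM is estimated, expected to lie between 2000 nM and 16000 nM.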

Compound 4, half-maximal inhibitory concentration: 2970 nM
Estimate against measurement, compound 4: 1.9-fold (0.27 log units) above; measured number inside the range.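

In this assay, (3-chlorophenyl)amino in place of dipropylamino on a double-bonded ring carbon gives an at least 5.3-fold lower number from compound 3 to compound 4 (0.73 log units; beyond the scatter), so the change lowers the number on this core as it does on the core of compound 1. Whether the size of the step carries over as well cannot be said, as the two steps stand: the same change on two cores in this assay, an at least 3.3-fold lower number (0.53 log units; beyond the scatter) from compound 1 to compound 2 and an at least 5.3-fold lower number (0.73 log units; beyond the scatter) from compound 3 to compound 4; the limit leaves it open whether they differ Each step starts from a limit, so the pairs show a direction and a minimum size but not the full size of either step: the limit of > 16000 nM in this assay, at which 2 of the 4 values shown sit.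

Open, on these data alone, is which part of the entering group goes with the lower numbers, since the change brings in the aromatic ring, the chlorine and the amine hydrogen together. Phenylamino without the chlorine, propylamino with its single chain and a cyclic amine such as morpholine would begin to separate these parts, and an amine that brings the dipropylamino compounds off the limit would allow the two steps to be sized.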